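The source may hold more compounds than are shown below. What is called first, only, known or untested is meant among the compounds shown, and "the series" means these compounds.

Compound 1 `c1ccc2c(-c3cn4ccnc4c(-c4ccc5ncn(C6CCCCC6)c5c4)n3)cccc2c1` and compound 2 `Clc1ccc(-c2cn3ccnc3c(-c3ccc4ncn(C5CCCCC5)c4c3)n2)cc1` share a core and differ only in the aromatic group carried on it. In a physicochemical assay for lipophilicity, using the shake flask method, in phosphate buffer, measured as octanol-water partition, with a stated time of 85 min, at pH 7.4 (on this read-out lower numbers stand for lower lipophilicity and higher numbers for higher lipophilicity), compound 1 gives 1.44, and compound 2 gives 1.51. Within the data shown here, of the two numbers, the one for compound 1 is the lower, but the distance to compound 2 is small: a number 0.07 log units higher from compound 1 to compound 2 (within the scatter), so the two cannot be told apart.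

Compound 3 `COc1ccccc1-c1cn2ccnc2c(-c2ccc3ncn(C4CCCCC4)c3c2)n1` is not yet measured in this assay. It comes from compound 1 by this change: 2-methoxyphenyl in place of naphthalen-1-yl on an aromatic carbon.

Among the measured compounds shown here, the only measured step that bears on this is the one from compound 1 to compound 2, where one aromatic group replaced another at the same place and the number moved by a number 0.07 log units higher from compound 1 to compound 2 (within the scatter). That change gave no shift beyond the scatter, and the change to compound 3 is of the same kind, exchanging the group at that same carbon. A step of a number 0.14 log units lower from compound 1 to compound 3 (within the scatter) is therefore expected, which is no shift beyond the scatter. Compound 3 is estimated at 1.3, with a range from 0.9 to 1.7.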

Compound 3, partition coefficient: 1.72
Estimate against measurement, compound 3: 0.42 log units below; the whole stated range lies below it.
By their numbers in this assay, from the lowest: compounds 1, 2 and 3 (each within the scatter of the next).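

In this assay, the new group at this carbon again gives no step beyond the scatter: the exchange of naphthalen-1-yl for 2-methoxyphenyl gives a number 0.28 log units higher from compound 1 to compound 3 (within the scatter), and the exchange of 4-chlorophenyl for 2-methoxyphenyl gives a number 0.21 log units higher from compound 2 to compound 3 (within the scatter). This extends what the first pair showed, since all three compounds now lie within the scatter of their neighbours, even though this change swaps two six-membered aromatic rings of carbon only for one such ring, and a group with no hydrogen-bond acceptor for one that has one. Nothing available here explains why these numbers lie so close together.

All three groups shown are built on aromatic carbon rings, so the compounds say nothing about whether a different kind of group at this carbon, such as an amine, a carboxylic acid or a longer alkyl chain, would give a step beyond the scatter. They also leave open whether a methoxy group elsewhere on the phenyl ring, as in 4-methoxyphenyl, would read the same as 2-methoxyphenyl.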